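The source may report more compounds than this note shows. Statements on the series, on what has been measured and on what is new or still open speak of the compounds shown alone.

Among the compounds with values here, compound 1 `CNc1ccccc1S(=O)(=O)c1ccccc1` is one of two compounds measured in a functional assay on HEK293 cells for antagonist activity at 5-hydroxytryptamine receptor 6 (Homo sapiens), read by cAMP accumulation, with a stated time of 30 min; on this read-out higher numbers stand for weaker inhibition and lower numbers for stronger inhibition. In this assay compound 1 gives 24.3 nM, the lower of the two numbers. Compound 2 `CN(C)c1ccccc1S(=O)(=O)c1ccccc1`, which carries a second methyl on the nitrogen of the methylamino group, gives 2040 nM in this assay, so that an 84-fold higher number from compound 1 to compound 2 (1.92 log units; beyond the scatter).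

Compound 3 `CNc1cc(-c2cccnc2)ccc1S(=O)(=O)c1ccccc1` differs from compound 1 in another place: pyridin-3-yl in place of hydrogen on an aromatic carbon. Within the data shown here, the only measured step, the one from compound 1 to compound 2, concerns the nitrogen and not the ring carbon that changes here, so it does not bear on this change, and there is no measured step that does. What is expected for compound 3 in this assay therefore rests on compound 1 alone, and the estimated step is a 1.6-fold lower number from compound 1 to compound 3 (0.21 log units; within the scatter), with most of the range close to compound 1 itself. Compound 3 is expected to give about 15 nM in this assay, estimated between 3 nM and 80 nM.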

Compound 3, inhibition constant: 48.3 nM
Estimate against measurement, compound 3: 3.2-fold (0.51 log units) below, within the range that was stated.
By their numbers in this assay, from the lowest: compounds 1 and 3 (each within the scatter of the next); then compound 2.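

In this assay, pyridin-3-yl in place of hydrogen on this aromatic carbon gives a 2.0-fold higher number from compound 1 to compound 3 (0.30 log units; within the scatter). This step lies within the scatter, so the position, meta to the methylamino group and para to a group of 9 heavy atoms, carries a whole aromatic ring with no change that can be told apart from repeat measurement, whereas the earlier step on the nitrogen lay beyond the scatter. Nothing shown here offers a reason for this result.

The compounds shown leave open whether the ring nitrogen of pyridin-3-yl matters, which a plain phenyl or a pyridin-4-yl on the same carbon would test, and whether a non-aromatic group such as piperazine or a simple amine would fit there as well. Going by these compounds, it also remains open how a second methyl on the nitrogen would behave with the pyridin-3-yl in place.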